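Quinolinyl for methylpyrazolyl: expected liver clearance of compound 4

A few compounds are considered here, and "the series" means these few. Any claim that something is new, unique, unknown or untested is made for them only; others in the source may bear on it.

compound 1 `CC(c1c(F)cc2ncccc2c1F)n1cnc2ncc(-c3cnn(C)c3)nc21` 11 uL/min
compound 2 `CC(c1c(F)cc2ncccc2c1F)n1cnc2ncc(-c3cnn(CCO)c3)nc21` 2 uL/min
compound 3 `CC(c1cc2cccnc2cc1F)n1cnc2ncc(-c3ccc(C(N)=O)c(F)c3)nc21` 14 uL/min

In an ADME assay on microsomes from liver (Homo sapiens) for metabolic stability, read by LC-MS, using NADPH, with stated times of 5 min and 30 min, tested at 1 uM (a higher number here means faster removal of the compound, a lower number slower removal), compound 1 gives 11 uL/min, the second highest of the three numbers; compound 3 gives 14 uL/min, within the scatter of compound 1, while compound 2 gives 2 uL/min. For the measured compounds named here, the only single-place step, a 5.5-fold lower number from compound 1 to compound 2 (0.74 log units; beyond the scatter), concerns hydroxymethyl in place of hydrogen and does not bear on the change to compound 4 `CC(c1c(F)cc2ncccc2c1F)n1cnc2ncc(-c3cnc4ccccc4c3)nc21`, which is quinolin-3-yl in place of 1-methyl-1H-pyrazol-4-yl on an aromatic carbon. Going by the values given here, no measured step covers quinolin-3-yl entering for 1-methyl-1H-pyrazol-4-yl, so the expectation rests on compound 1 alone and carries wide uncertainty. For compound 4 the expected step is a 1.8-fold higher number from compound 1 to compound 4 (0.26 log units; within the scatter), towards a higher number. Compound 4 is therefore estimated at 20 uL/min, between 8 uL/min and 50 uL/min.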

Compound 4, intrinsic clearance in a liver preparation (reported as CLH), per the amount of preparation that the assay uses: 51 uL/min
For compound 4 the middle estimate is 2.6-fold (0.41 log units) below the measured one, and the stated range ends below it.
By their numbers in this assay, from the lowest: compound 2; then compounds 1 and 3 (each within the scatter of the next); then compound 4.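

Replacing the whole group on this aromatic carbon, not just the chain on the pyrazole, shows that the position itself can shift the number in this assay: quinolin-3-yl gives a 4.6-fold higher number from compound 1 to compound 4 (0.67 log units; beyond the scatter). Measured against 1-(2-hydroxyethyl)-1H-pyrazol-4-yl, the same group gives a 26-fold higher number from compound 2 to compound 4 (1.41 log units; beyond the scatter), the largest step among these compounds. Nothing available explains this rise.

The compounds shown leave open whether the second ring of quinolin-3-yl matters, which a single pyridin-3-yl ring at this place would test. They also leave open whether a hydroxyethyl chain or an amine on the quinoline would bring the number down.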